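Swapping Thiophen-2-yl for Furan-2-yl in Compound 3

This account rests on a few compounds, and the source may have more. Where it says the series, first, only, none or still open, it means among the compounds named here.

Compound 3 `Oc1ccc(-c2cc(-c3ccc(Cl)cc3)nc(-c3cccs3)c2)cc1` gives the highest of the three numbers in an assay on isolated protein for inhibition of DNA topoisomerase 1 (Homo sapiens), with a stated time of 30 min, tested at 100 uM (a lower number here means a weaker effect, a higher number a stronger effect of the compound at the concentration tested), namely 38.8%. Compound 2 `Oc1cccc(-c2cc(-c3ccc(Cl)cc3)nc(-c3cccs3)c2)c1` gives 15.1% and compound 1 `Oc1ccc(-c2cc(-c3cccs3)nc(-c3ccccc3Cl)c2)cc1` gives 2.2%; the steps of a number 23.7 percentage points higher from compound 2 to compound 3 (beyond the scatter) and a number 36.6 percentage points higher from compound 1 to compound 3 (beyond the scatter) both lie beyond the scatter. Compound 4 `Oc1ccc(-c2cc(-c3ccc(Cl)cc3)nc(-c3ccco3)c2)cc1` differs from compound 3 by furan-2-yl in place of thiophen-2-yl on an aromatic carbon. Neither measured step touches this part of the molecule: one exchanges 2-chlorophenyl for 4-chlorophenyl, the other 3-hydroxyphenyl for 4-hydroxyphenyl, so the data give no direct guide to the furan-2-yl for thiophen-2-yl exchange. Relative to compound 3, compound 4 is expected to show a step of a number 8.8 percentage points lower from compound 3 to compound 4 (within the scatter), small enough that it may fall within the scatter. In this assay compound 4 is estimated at 30%, within 10% to 55%.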

Compound 4, a percentage reported as inhibition, at one concentration (the size of the read-out at that concentration, not a potency): 15.8%
Compound 4: middle estimate off by 14.2 percentage points, on the high side; the range from low to high includes it.
By their numbers in this assay, from the lowest: compound 1; then compounds 2 and 4 (each within the scatter of the next); then compound 3.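

In this assay the position next to the ring nitrogen proves sensitive to the five-membered ring it carries (a number 23 percentage points lower from compound 3 to compound 4 (beyond the scatter)), although furan-2-yl and thiophen-2-yl match in heavy atoms and counted hydrogen-bond acceptors. The earlier steps shown here followed only the chlorine and the hydroxyl; this one shows that exchanging sulfur for oxygen in that ring alone lowers the number beyond the scatter. Nothing measured here accounts for the drop.

As far as these compounds go, it remains open whether a phenyl or a methyl at this position would keep the number of compound 3, and whether thiophen-2-yl keeps its edge over furan-2-yl alongside the other chlorophenyl and hydroxyphenyl arrangements.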